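The compounds below may be only part of what the source reports. "The series", "measured", "known", "first", "only" and "open" are said of these compounds alone.

Compound 1 `COc1ccc(CN2C(=O)C(=O)c3c(-c4ccc(OC)cc4)cccc32)cc1`: in a functional assay on K562 cells (Homo sapiens) for antiproliferative activity, read by MTT assay, with a stated time of 48 h (a higher number here means a weaker inhibitor, a lower number a stronger inhibitor), compound 1 gives > 10000 nM, which is a limit of the assay rather than a number.
Compound 2 `COc1ccc(CN2C(=O)C(=O)c3cc(-c4cc(OC)cc(OC)c4)ccc32)cc1`: in this assay compound 2 gives 510 nM.

For the measured compounds named here, compound 2 stands alone as the only numerical value shown; the other result, (the limit of > 10000 nM in this assay, at which 1 of the 2 values shown sits), is a limit. Compound 3 `COc1ccc(CN2C(=O)C(=O)c3cc(-c4ccc(O)cc4)ccc32)cc1` has not yet been measured. It differs from compound 2 in one place: 4-hydroxyphenyl in place of 3,5-dimethoxyphenyl on an aromatic carbon. The 4-hydroxyphenyl sits on an aromatic carbon of a six-membered aromatic ring of carbon only, part of a fused or bridged system of two rings, meta to a fused ring and para to a fused ring. Going by the values given here, no measured pair here shows how such a swap plays out, so the expectation rests on the change itself. A modest loss of activity is expected, the step of a 2.9-fold higher number from compound 2 to compound 3 (0.47 log units; beyond the scatter) being estimated as small to moderate toward a weaker inhibitor. Compound 3 is expected to give about 1500 nM, within a range of 400 nM to 6000 nM.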

Compound 3, half-maximal inhibitory concentration: 60 nM
Beside the measured number, compound 3's estimate is 25-fold (1.40 log units) above it, and the stated range ends above it.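

In this assay, putting 4-hydroxyphenyl in place of 3,5-dimethoxyphenyl on this aromatic carbon gives an 8.5-fold lower number from compound 2 to compound 3 (0.93 log units; beyond the scatter), which shows that activity at this position responds clearly to the choice of aryl group. The change also shows that the larger group with two methoxy substituents is not needed for activity in this pair, since the group with fewer heavy atoms gives the stronger inhibitor. The measured values give no explanation for this gain in activity.

This single step cannot separate the effect of gaining the hydroxy group from that of losing the two methoxy groups. From the compounds shown here alone, it also remains open whether a phenyl ring carrying an amine or a carboxylic acid in place of the hydroxy group would keep this activity.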